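A few compounds are considered here, and "the series" means these few. Any claim that something is new, unique, unknown or untested is made for them only; others in the source may bear on it.

Measured compounds:
compound 1, `CS(=O)(=O)Nc1ccc(C/N=C(\S)NCc2ccccc2)cc1F`: 9700 nM
compound 2, `CS(=O)(=O)Nc1ccc(C/N=C(\S)NCc2ccc(I)cc2)cc1F`: 630 nM

In an assay for inhibition of transient receptor potential cation channel subfamily V member 1 (Rattus norvegicus), with a stated time of 10 min (on this read-out higher numbers stand for weaker inhibition and lower numbers for stronger inhibition), compound 1 gives 9700 nM, the highest of the two numbers, so it stands as the weaker inhibitor of the pair; compound 2, the nearest neighbour, gives 630 nM in this assay. Compound 3, `CS(=O)(=O)Nc1ccc(C/N=C(\S)NC(c2ccccc2)c2ccccc2)cc1F`, is not yet measured. It differs from compound 1 in one place: phenyl in place of hydrogen on a saturated chain carbon bound to an amine nitrogen and an aromatic carbon. For the measured compounds named here, the only measured step available runs from compound 1 to compound 2, where a 15-fold lower number from compound 1 to compound 2 (1.19 log units; beyond the scatter). That step changes a different place, an aromatic carbon rather than the saturated chain carbon, and adds a different group, so it bears on the new change only indirectly: it shows that adding a group on the benzyl side of the shared core lowered the number strongly. A second phenyl at the chain carbon is a larger addition at a new place, so a lowering in this assay is expected, though its size is uncertain and likely below that of the iodo step. For compound 3 the number in this assay is estimated at 2500 nM, with a range from 600 nM to 10000 nM, which means an expected step of a 3.9-fold lower number from compound 1 to compound 3 (0.59 log units; beyond the scatter).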

Compound 3, half-maximal inhibitory concentration: 2500 nM
For compound 3 middle estimate and measured number coincide at the digits printed; the range from low to high includes it.
By their numbers in this assay, from the lowest: compound 2; then compound 3; then compound 1.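

In this assay the saturated chain carbon bound to an amine nitrogen and an aromatic carbon tolerates a much larger group than hydrogen: placing phenyl there gives a 3.9-fold lower number from compound 1 to compound 3 (0.59 log units; beyond the scatter) and so strengthens inhibition rather than losing it. For the compounds shown here, until now the only change on show was iodo in place of hydrogen on an aromatic carbon, which gave a 15-fold lower number from compound 1 to compound 2 (1.19 log units; beyond the scatter) as a large step, while this modest step shows that a second place on the shared core also responds to substitution. Nothing available here explains why either number falls, so the cause of this change remains unknown.

Whether a methyl group or a hydroxyl group on this same chain carbon would give a step of similar size stays open, so the compounds shown cannot tell whether an aromatic ring is needed here or whether a smaller group would do as well. It is also open whether iodo on an aromatic carbon of compound 3 would add to the effect of the phenyl, since no compound shown carries both groups.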